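A Nitrooxymethyl Ester in Place of the Pyridyl Ester

The source may report more compounds than this note shows. Statements on the series, on what has been measured and on what is new or still open speak of the compounds shown alone.

Three esters of a shared core have been measured in an ADME assay on a cell-free system (plasma, Homo sapiens) for metabolic stability, with Plasma (Rattus norvegicus) as the target, read by HPLC, at pH 7.4; a higher number here means that the compound lasts longer, a lower number that the compound disappears faster. Compound 1 `CC(=O)Oc1ccccc1C(=O)O[C@H]1CO[C@H]2[C@@H]1OC[C@H]2OC(=O)C1CC1` gives 0.0322 h. Compound 3 `CC(=O)Oc1ccccc1C(=O)O[C@H]1CO[C@H]2[C@@H]1OC[C@H]2OC(=O)c1ccncc1` gives 0.0617 h, the higher of the two plain numbers, yet the step of a 1.9-fold higher number from compound 1 to compound 3 (0.28 log units; within the scatter) lies within the scatter, so the two cannot be ordered. Compound 2 `CC(=O)Oc1ccccc1C(=O)O[C@H]1CO[C@H]2[C@@H]1OC[C@H]2OC(=O)c1ccc(-c2ccccc2)cc1` reaches only a limit of the assay, > 0.333 h. The steps of an at least 10-fold higher number from compound 1 to compound 2 (1.01 log units; beyond the scatter) and an at least 5.3-fold lower number from compound 2 to compound 3 (0.73 log units; beyond the scatter) show that the 4-phenylphenyl ester stands apart from the other two.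

Compound 4 `CC(=O)Oc1ccccc1C(=O)O[C@H]1CO[C@H]2[C@@H]1OC[C@H]2OC(=O)CO[N+](=O)[O-]` differs from compound 3 in one place: (nitrooxy)methyl in place of pyridin-4-yl on a carbonyl carbon. Among the compounds with values here, no measured step brings in a group without a ring, so the only guide is that the cyclopropyl ester of compound 1 and the pyridin-4-yl ester of compound 3 sit close together, whereas the 4-phenylphenyl ester moves far. The entering (nitrooxy)methyl group, like cyclopropyl, carries no ring, so compound 4 is expected to stay near compound 3, with a step of a 1.5-fold lower number from compound 3 to compound 4 (0.19 log units; within the scatter) that remains within the scatter. Compound 4 is therefore estimated at 0.04 h, with a range from 0.015 h to 0.1 h.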

Compound 4, half-life: 0.06 h
Compound 4: the middle estimate sits 1.5-fold (0.18 log units) below what was measured; the range from low to high includes it.
By their numbers in this assay, from the lowest: compounds 1, 4 and 3 (each within the scatter of the next). At a limit, above all of these: compound 2.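

In this assay, the step at this carbonyl carbon is a 1.0-fold lower number from compound 3 to compound 4 (0.01 log units; within the scatter), and from the cyclopropyl ester it is a 1.9-fold higher number from compound 1 to compound 4 (0.27 log units; within the scatter), so a group with no ring falls together with the two esters that carry a single ring. Having a ring or not therefore does not separate these three esters, and only the 4-phenylphenyl ester remains apart, with an at least 5.5-fold lower number from compound 2 to compound 4 (0.74 log units; beyond the scatter). The figure for compound 2 is a limit and not a number: the limit of > 0.333 h in this assay, at which 1 of the 4 values shown sits.

How far compound 2 really stands from the others stays open for that reason. Also open, as far as these compounds go, is where a plain phenyl ester or a longer chain, such as a hexyl ester, would fall, and so which feature of the 4-phenylphenyl group goes with its separate place.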